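Comparing an Ether-Linked Heteroaryl Tail With a Benzamido Group

This account rests on a few compounds, and the source may have more. Where it says the series, first, only, none or still open, it means among the compounds named here.

Of the compounds shown here, three that share one core have been tested in a functional assay on HEK293 cells for agonist activity at G-protein coupled receptor 39 (Homo sapiens), read by scintillation proximity assay and inositol phosphate accumulation, with a stated time of 75 min, in the presence of a further agent that is not named here; on this read-out higher numbers stand for an effect only at larger amounts of compound and lower numbers for an effect already at smaller amounts. Compound 1 `Cc1nn(-c2ncnc3nc[nH]c23)c2c1C(OC1CCCC1)CC(=O)N2` gives 2 nM. Compound 2 `Cc1nn(-c2ncnc3nc[nH]c23)c2c1C(OCc1ccc(C(C)C)cc1)CC(=O)N2` gives 5 nM. Compound 3 `Cc1nn(-c2ncnc3nc[nH]c23)c2c1C(NC(=O)c1ccccc1)CC(=O)N2` gives 3 nM, the second highest of the three numbers, within the scatter of both others. Compound 4 `Cc1nn(-c2ncnc3nc[nH]c23)c2c1C(OCCn1nccc1C)CC(=O)N2` differs from compound 3 by a group of 9 heavy atoms (6 carbon, 2 nitrogen, 1 oxygen; one five-membered aromatic ring with 2 hetero atoms) in place of a group of 9 heavy atoms (7 carbon, 1 nitrogen, 1 oxygen; one six-membered aromatic ring of carbon only), on a saturated ring carbon. For the measured compounds named here, two measured steps bear on this: a 1.5-fold higher number from compound 1 to compound 3 (0.18 log units; within the scatter), which exchanges the group on the saturated ring carbon, and a 2.5-fold higher number from compound 1 to compound 2 (0.40 log units; beyond the scatter), which exchanges the group on the oxygen on a saturated carbon. Both steps are small, so no change beyond the scatter is expected here, namely a 1.3-fold higher number from compound 3 to compound 4 (0.12 log units; within the scatter). Compound 4 is therefore estimated at 4 nM, with a range from 1.5 nM to 12 nM.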

Compound 4, half-maximal effective concentration: 10 nM
Beside the measured number, compound 4's estimate is 2.5-fold (0.40 log units) below it; the measured number falls inside the stated range.
By their numbers in this assay, from the lowest: compounds 1, 3, 2 and 4 (each within the scatter of the next, the first and the last beyond it).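

Against the benzamido group, the (5-methyl-1H-pyrazol-1-yl)methyl ether tail gives the first change at this saturated ring carbon that lies beyond the scatter, with a 3.3-fold higher number from compound 3 to compound 4 (0.52 log units; beyond the scatter). For the compounds shown here, on the oxygen, this tail gives the largest step so far, a 5.0-fold higher number from compound 1 to compound 4 (0.70 log units; beyond the scatter), whereas in place of 4-isopropylphenyl it gives a 2.0-fold higher number from compound 2 to compound 4 (0.30 log units; within the scatter), so those two ether tails cannot be separated. No available evidence accounts for these steps. On these data alone, it remains open whether the methyl on the pyrazole ring matters, and whether an amine or a carboxylic acid on this saturated ring carbon would keep the numbers this low.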